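This account rests on a few compounds, and the source may have more. Where it says the series, first, only, none or still open, it means among the compounds named here.

Of the compounds shown here, three have so far been tested in a functional assay on HCT-116 cells (Homo sapiens) for cytotoxicity, read by MTT assay, with a stated time of 48 h; a higher number here means a weaker inhibitor, a lower number a stronger inhibitor. Compound 1 `C=CCOc1ccc2c(NCCCN(C)C)ccnc2c1` gives 2100 nM, compound 2 `CCCCCCOc1ccc2c(NCCN(C)C)ccnc2c1` gives 850 nM, and compound 3 `CN(C)CCCNc1ccnc2cc(OCc3ccc(F)cc3)ccc12` gives 740 nM. Compound 3 thus shows the lowest number of the three, but its gap to compound 2 lies within the scatter, so these two cannot be ranked against each other; the gap to compound 1 is larger, a 2.8-fold lower number from compound 1 to compound 3 (0.45 log units; beyond the scatter), a step that comes from putting 4-fluorophenyl in place of vinyl on a saturated chain carbon bound to an oxygen on an aromatic ring.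

Compound 4 `CN(C)CCNc1ccnc2cc(OCc3ccc(F)cc3)ccc12` keeps everything of compound 3 except the chain that carries the dimethylamino group: dimethylamino in place of (dimethylamino)methyl on a saturated chain carbon, two bonds along the chain from a nitrogen on an aromatic ring. Going by the values given here, none of the measured steps touches this part of the molecule. Compound 1 and compound 2 do differ from one another at this chain, yet they also differ at the group on the oxygen, so their two values give no clean reading of the chain alone. Among the compounds with values here, with no step to lean on, no movement beyond the scatter in this assay is expected, and the step of a 1.1-fold lower number from compound 3 to compound 4 (0.02 log units; within the scatter) is therefore estimated as small. Compound 4 is expected to give about 700 nM, most likely between 300 nM and 1600 nM.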

Compound 4, half-maximal inhibitory concentration in the HCT-116 assay: 370 nM
Beside the measured number, compound 4's estimate is 1.9-fold (0.28 log units) above it, within the range that was stated.
By their numbers in the HCT-116 assay, from the lowest: compounds 4, 3 and 2 (each within the scatter of the next, the first and the last beyond it); then compound 1.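

Going by these compounds alone, in the HCT-116 assay, this is the first clean reading of the chain alone: (2-(dimethylamino)ethyl)amino in place of (3-(dimethylamino)propyl)amino gives a 2.0-fold lower number from compound 3 to compound 4 (0.30 log units; within the scatter) and so stays within what repeated measurements would scatter, whereas with the 2-(dimethylamino)ethyl chain held fixed, 4-fluorophenyl in place of pentyl on the carbon bound to the oxygen gives a 2.3-fold lower number from compound 2 to compound 4 (0.36 log units; beyond the scatter) and so is a modest step beyond the scatter. In a physicochemical assay for solubility (on this read-out lower numbers stand for lower solubility and higher numbers for higher solubility), compound 3 gives > 10000 ug/mL and this is a limit of the assay, not a number. In the physicochemical assay compound 4 gives > 10000 ug/mL and this too is a limit of the assay, not a number.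

The step between these two compounds on solubility cannot be read, because both values sit at the same limit: the limit of > 10000 ug/mL in the physicochemical assay, at which 2 of the 2 values shown sit. Still open, as far as these compounds go, is whether a 4-(dimethylamino)butyl chain, or diethylamino in place of dimethylamino, would move the number in the HCT-116 assay beyond the scatter around compound 4 .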